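Dichlorophenyl in place of fluorophenyl on the triazole nitrogen

This account rests on a few compounds, and the source may have more. Where it says the series, first, only, none or still open, it means among the compounds named here.

Of the compounds shown here, three sharing one core have been tested in a functional assay on NCI-H460 cells (Homo sapiens) for cytotoxicity, read by MTT assay, with a stated time of 72 h; a higher number here means a weaker inhibitor, a lower number a stronger inhibitor. Compound 1 `COc1cc2c(Oc3ccc(NC(=O)c4cn(-c5c(Cl)cccc5Cl)nn4)cc3F)ccnc2cc1OCCCN1CCCCC1` gives 280 nM. Compound 2 `COc1cc2c(Oc3ccc(NC(=O)c4cn(-c5ccccc5)nn4)cc3F)ccnc2cc1OCCCN1CCC(C)CC1` gives 210 nM, and compound 3 `COc1cc2c(Oc3ccc(NC(=O)c4cn(-c5ccccc5F)nn4)cc3F)ccnc2cc1OCCCN1CCC(C)CC1` gives 190 nM. Compound 3 sits at the low end of the three numbers, but the gaps to compound 2 and to compound 1 both lie within the scatter, so the three cannot be told apart with confidence. Going by the values given here, the only single-point step available, a 1.1-fold lower number from compound 2 to compound 3 (0.04 log units; within the scatter), is itself within the scatter.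

Compound 4 `COc1cc2c(Oc3ccc(NC(=O)c4cn(-c5c(Cl)cccc5Cl)nn4)cc3F)ccnc2cc1OCCCN1CCC(C)CC1` has not yet been measured. It differs from compound 3 in one place: 2,6-dichlorophenyl in place of 2-fluorophenyl on an aromatic nitrogen. Among the compounds with values here, no measured pair shows this exact swap. Compound 1 carries the same 2,6-dichlorophenyl as compound 4 but differs from it elsewhere, so its value can only be read as a rough hint; together with compound 2 and compound 3 it suggests that changes at this aromatic nitrogen have so far moved this assay little. The expected step of a 1.3-fold higher number from compound 3 to compound 4 (0.10 log units; within the scatter) is therefore small, most likely within the scatter, with no firm direction. Compound 4 is estimated at 240 nM, with a likely range from 120 nM to 480 nM.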

Compound 4, half-maximal inhibitory concentration: 270 nM
Estimate against measurement, compound 4: 1.1-fold (0.05 log units) below, and the stated range covers the measured number.
By their numbers in this assay, from the lowest: compounds 3, 2, 4 and 1 (each within the scatter of the next).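

With the rest of the molecule held the same, three groups on this aromatic nitrogen of the five-membered ring can now be compared directly in this assay. The change to 2,6-dichlorophenyl gives a 1.4-fold higher number from compound 3 to compound 4 (0.15 log units; within the scatter), and starting from plain phenyl it gives a 1.3-fold higher number from compound 2 to compound 4 (0.11 log units; within the scatter), so phenyl, 2-fluorophenyl and 2,6-dichlorophenyl cannot be told apart here, even though the last of these carries two chlorine atoms. The methyl on the saturated ring carbon also gets its first direct test, with a 1.0-fold lower number from compound 1 to compound 4 (0.02 log units; within the scatter), and nothing measured here bears on why any of these steps is so small.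

From the compounds shown here alone, all three groups on this nitrogen contain a six-membered aromatic ring of carbon only, so it remains open whether a plain methyl, a cyclohexyl group or a phenyl bearing a carboxylic acid would also leave the number in the same range. Going by these compounds, it is equally open whether a hydroxyl or an amine in place of the methyl on the saturated ring carbon would shift the result in this assay by more than the scatter.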